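The compounds below may be only part of what the source reports. "The series", "measured", "known", "first", "only" and "open" are said of these compounds alone.

In a functional assay on HCT-116 cells (Homo sapiens) for antiproliferative activity, read by MTT assay, with a stated time of 48 h (a lower number here means a stronger inhibitor, a higher number a weaker inhibitor), compound 1 `CCCCCCCC(CCO)n1cnc2c(Cl)ncnc21` gives 4160 nM, compound 2 `CCCCCCC[C@H](CCO)n1cnc2c(Cl)ncnc21` gives 2670 nM and compound 3 `CCCCCCCCC(CCO)n1cnc2c(Cl)nc(F)nc21` gives 24200 nM. On these numbers, compound 2 sits level with compound 1 and well under compound 3. Compound 4 `CCCCCCCC[C@H](CCO)n1cnc2c(Cl)ncnc21` departs from compound 2 by methyl in place of hydrogen on a saturated chain carbon, eight bonds along the chain from an aromatic nitrogen, that is, methyl in place of hydrogen on a saturated chain carbon. Going by the values given here, the only single-place step measured, a 1.6-fold lower number from compound 1 to compound 2 (0.19 log units; within the scatter), concerns the fact that one of compounds 1 and 2 is drawn with a defined configuration and the other without, at the place where they differ and not chain length. Compound 3 differs from compound 2 in more than one place, so its value does not size this change. The expected step is a 1.1-fold higher number from compound 2 to compound 4 (0.05 log units; within the scatter), with no shift beyond the scatter anticipated in this assay. For compound 4 the estimate is 3000 nM, with an expected range of 1200 nM to 9000 nM.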

Compound 4, half-maximal inhibitory concentration: 1120 nM
Compound 4: the middle estimate sits 2.7-fold (0.43 log units) above what was measured; the whole stated range lies above it.
By their numbers in this assay, from the lowest: compound 4; then compounds 2 and 1 (each within the scatter of the next); then compound 3.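

Methyl in place of hydrogen on a saturated chain carbon, eight bonds along the chain from an aromatic nitrogen, gives a 2.4-fold lower number from compound 2 to compound 4 (0.38 log units; beyond the scatter) in this assay as the first single-place step here that changes chain length. Both compounds carry a drawn configuration, so this step is not a contrast of defined against undefined stereo, and the position accepts the extra carbon with a lower number. Nothing available bears on the reason for this step. On these data alone, whether a longer chain lowers the number further, and how an amine or a carboxylic acid fares at this place, stays open.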